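The source may hold more compounds than are shown below. What is called first, only, known or untested is meant among the compounds shown, and "the series" means these compounds.

Compound 1 `CCCSc1nc(N)nc2c1ncn2/C=C1/CC1(CO)CO` was tested in an ADME assay on BCBL1 cells (Homo sapiens) for cytotoxicity, with a stated time of 7 days (on this read-out lower numbers stand for higher toxicity in this test and higher numbers for lower toxicity in this test), where compound 1 gives > 20000 nM, which is a limit of the assay rather than a number. Compound 2 `CCCCCCSc1nc(N)nc2c1ncn2/C=C1/CC1(CO)CO` in this assay gives > 20000 nM, also a limit. Compound 3 `Nc1nc2c(ncn2/C=C2/CC2(CO)CO)c(=O)[nH]1` in this assay gives > 20000 nM, again a limit. Within the data shown here, because of the limit of > 20000 nM in this assay, at which 3 of the 3 values shown sit, compound 1 stands at the same limit as every other compound measured here, and the one step between measured compounds, a step that the two limits leave unreadable from compound 1 to compound 2, cannot be read as a size. The compound still to be measured, compound 4 `CCCCCCOc1nc(N)nc2c1ncn2/C=C1/CC1(CO)CO`, differs from compound 1 by hexyloxy in place of propylsulfanyl on an aromatic carbon. Among the measured compounds shown here, no measured step bears on this change in a readable way, since every value shown is a limit. The expectation is therefore a step of a number no higher from compound 1 to compound 4 (the limit leaves the size open) that stays within the scatter, so that compound 4 is expected to sit at the same limit as compound 1. For compound 4 in this assay the estimate is 20000 nM, between 10000 nM and 40000 nM.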

Compound 4, half-maximal cytotoxic concentration: > 20000 nM
Compound 4: a limit, no number (the forecaster's own chance of this, stated with the estimate: 85%); the middle value sits exactly at the limit.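

Compound 4 sits at the same limit as compound 1 and compound 2, so neither step to compound 4 can be read as a size: the limit of > 20000 nM in this assay, at which 4 of the 4 values shown sit. The compounds shown leave open whether swapping these side chains changes the toxicity in this assay in any way.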